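The compounds below may be only part of what the source reports. "The series", "measured", "known", "first", "only" and "open" are said of these compounds alone.

Measured in a functional assay on CCRF-CEM cells (Homo sapiens) for cytotoxicity; on this read-out lower numbers stand for stronger inhibition and higher numbers for weaker inhibition:
- Compound 1 `Nc1ccn([C@@H]2C=C(F)[C@H](CO)O2)c(=O)n1`: > 100000 nM, a limit
- Compound 2 `Nc1nc(=O)n([C@@H]2C=C(F)[C@H](CO)O2)cc1F`: > 100000 nM, a limit

Compound 1 is known only as a limit, > 100000 nM. It shares this position with compound 2: the limit of > 100000 nM in this assay, at which 2 of the 2 values shown sit. Compound 3 `O=c1nc(O)ccn1[C@@H]1C=C(F)[C@H](CO)O1` carries hydroxy in place of amino on an aromatic carbon. Among the compounds with values here, the only measured step, a step that the two limits leave unreadable from compound 1 to compound 2, has no readable size and involves a different change, so it gives no measure for this one. No step beyond the scatter is therefore expected in this assay, in either direction. The estimated step is a number no higher from compound 1 to compound 3 (the limit leaves the size open). For compound 3 the expected value is 100000 nM, with an estimated range of 50000 nM to 200000 nM.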

Compound 3, half-maximal inhibitory concentration: 30100 nM
The estimate for compound 3 lay 3.3-fold (0.52 log units) above the measured number; measured number below the stated range.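

In this assay, hydroxy in place of amino on an aromatic carbon gives an at least 3.3-fold lower number from compound 1 to compound 3 (0.52 log units; beyond the scatter). Within the data shown here, this shows that a change at this place, opposite the ring nitrogen, can bring a number off the limit and towards stronger inhibition, which the earlier compounds could not show. Compound 3 alone carries a measured number, while compound 1 and compound 2 stay at a limit: the limit of > 100000 nM in this assay, at which 2 of the 3 values shown sit.

From the compounds shown here alone, the full size of the step stays open, as compound 1 is known only as a limit. Going by these compounds, whether methoxy or methylamino at this place would lower the number further also remains open.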